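This account rests on a few compounds, and the source may have more. Where it says the series, first, only, none or still open, it means among the compounds named here.

Compound 1 `COc1ccc(/C=N/NC(=O)Nc2ccc(Oc3ccnc4cc(OCCCN5CCCCC5)c(OC)cc34)c(F)c2)cc1`: in a functional assay on A549 cells (Homo sapiens) for cytotoxicity, read by MTT assay, with a stated time of 72 h (a higher number here means a weaker inhibitor, a lower number a stronger inhibitor), compound 1 gives 540 nM.
Compound 2 `COc1cc2c(Oc3ccc(NC(=O)N/N=C/c4ccc(Cl)cc4Cl)cc3F)ccnc2cc1OCCCN1CCCCC1`: in this assay compound 2 gives "not determined" (no result reported).
Compound 3 `COc1cc2c(Oc3ccc(NC(=O)N/N=C/c4ccc(OC(F)(F)F)cc4)cc3F)ccnc2cc1OCCCN1CCCCC1`: in this assay compound 3 gives 590 nM.

Compound 3 carries the higher of the two numbers reported in this assay, but its nearest neighbour, compound 1, sits so close that the two cannot be ordered; compound 2 contributes no number at all. Among the measured compounds shown here, the single measured step, a 1.1-fold higher number from compound 1 to compound 3 (0.04 log units; within the scatter), swaps the substituent on the oxygen of the aryl ring attached to the carbon double-bonded to nitrogen and stays within the scatter. Compound 4 `COc1ccc(/C=N/NC(=O)Nc2ccc(Oc3ccnc4cc(OCCCN5CCCCC5)c(OC)cc34)c(F)c2)c(OC)c1` is reached from compound 3 by the change (2,4-dimethoxyphenyl in place of 4-(trifluoromethoxy)phenyl on a carbon with a double bond to nitrogen). For the measured compounds named here, this again alters only the substitution of that same aryl ring, and the one step that bears on it, a 1.1-fold higher number from compound 1 to compound 3 (0.04 log units; within the scatter), was flat. No change beyond the scatter is therefore expected in this assay for compound 4, in either direction. The estimate for compound 4 is 560 nM, with a range from 250 nM to 1300 nM, which corresponds to an expected step of a 1.1-fold lower number from compound 3 to compound 4 (0.02 log units; within the scatter).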

Compound 4, half-maximal inhibitory concentration: 1400 nM
Estimate against measurement, compound 4: 2.5-fold (0.40 log units) below, outside the stated range (above it).
By their numbers in this assay, from the lowest: compounds 1 and 3 (each within the scatter of the next); then compound 4.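

In this assay the aryl ring on the carbon with a double bond to nitrogen turned out not to be indifferent to substitution: the change gives a 2.4-fold higher number from compound 3 to compound 4 (0.38 log units; beyond the scatter), whereas the earlier change on the oxygen stayed within the scatter. The closest comparison is with compound 1, where the only difference is methoxy in place of hydrogen on an aromatic carbon, and it gives a 2.6-fold higher number from compound 1 to compound 4 (0.41 log units; beyond the scatter), showing that this single added group is enough for a modest move towards a weaker number. Nothing measured here explains this shift.

The compounds shown leave open whether other groups on this ring, such as an amine or a carboxylic acid, would move the number in the same direction. They also leave open whether a longer chain on the oxygen would do so.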